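A few compounds are considered here, and "the series" means these few. Any claim that something is new, unique, unknown or untested is made for them only; others in the source may bear on it.

Compound 1, `Cc1cccc(NC(=O)Nc2ccc(Oc3ncnc4[nH]ncc34)cc2)c1C`, gives in an assay on isolated protein for inhibition of vascular endothelial growth factor receptor 2 (Danio rerio), read by fluorescence and microscopy, with a stated time of 33 h (on this read-out lower numbers stand for stronger inhibition and higher numbers for weaker inhibition), a value of 98800 nM.
Compound 2, `O=C(NCC1CCCCC1)Nc1ccc(Oc2ncnc3[nH]ncc23)cc1`, reaches only the assay's limit, > 100000 nM, in this assay.

Compound 2 thus stands at the weak end, where only a limit and no number is known. Compound 3, `O=C(Nc1ccc(Oc2ncnc3[nH]ncc23)cc1)Nc1cccc(F)c1`, differs from it by 3-fluorophenyl in place of cyclohexylmethyl on an amide-type nitrogen, bringing back an aromatic ring like that of compound 1. Going by the values given here, the one measured step that bears on it is an at least 1.0-fold higher number from compound 1 to compound 2 (0.00 log units; that floor lies within the scatter), a floor within the scatter, so the reverse direction is expected to give an at least 1.4-fold lower number from compound 2 to compound 3 (0.15 log units; that floor lies within the scatter), a slightly lower number. Compound 3 is therefore estimated at 70000 nM, within 15000 nM to 300000 nM.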

Compound 3, half-maximal inhibitory concentration: 16600 nM
Compound 3: the middle estimate sits 4.2-fold (0.62 log units) above what was measured; low and high end bracket the measured number.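

At this amide-type nitrogen, the identity of the aromatic ring matters, which the earlier pair could not show: a 6.0-fold lower number from compound 1 to compound 3 (0.77 log units; beyond the scatter). Replacing the non-aromatic cyclohexylmethyl also gives a step beyond the scatter: an at least 6.0-fold lower number from compound 2 to compound 3 (0.77 log units; beyond the scatter). Compound 2 gives only a limit, so this step is a floor and its full size is unknown: the limit of > 100000 nM in this assay, at which 1 of the 3 values shown sits.

Still open, on these data alone, is whether the fluorine itself contributes, which a plain phenyl would test. Also open, as far as these compounds go, is how a ring carrying an amine or a carboxylic acid would read in this assay.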